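The source may report more compounds than this note shows. Statements on the series, on what has been measured and on what is new or still open speak of the compounds shown alone.

Three close relatives of one shared core have been measured in a functional assay on PA-1 cells (Homo sapiens) for cytotoxicity, read by MTT assay, with a stated time of 24 h; on this read-out higher numbers stand for weaker inhibition and lower numbers for stronger inhibition. Compound 1 `Clc1nc(Nc2ccccc2)nc(Nc2ccc(-c3nc4ccccc4o3)cc2)n1` gives 169000 nM. Compound 2 `COc1ccc(Nc2nc(Cl)nc(Nc3ccc(-c4nc5ccccc5o4)cc3)n2)cc1`, which carries methoxy in place of hydrogen on an aromatic carbon, gives 172000 nM, and compound 3 `Fc1ccc(Nc2nc(Cl)nc(Nc3ccc(-c4nc5ccccc5o4)cc3)n2)cc1`, with fluoro in place of hydrogen on an aromatic carbon, gives 186000 nM. The three numbers sit close together: the step of a 1.0-fold higher number from compound 1 to compound 2 (0.01 log units; within the scatter), the step of a 1.1-fold higher number from compound 1 to compound 3 (0.04 log units; within the scatter) and the step of a 1.1-fold higher number from compound 2 to compound 3 (0.03 log units; within the scatter) all fall within the scatter, so compound 3 cannot be set apart from either companion on this read-out.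

Compound 4 `Clc1nc(NCc2ccccc2)nc(Nc2ccc(-c3nc4ccccc4o3)cc2)n1` has not yet been measured. It differs from compound 3 by benzyl in place of 4-fluorophenyl on a nitrogen on an aromatic ring; the nitrogen on the aromatic ring, whose other neighbour is an aromatic carbon, now carries benzyl rather than 4-fluorophenyl. Among the compounds with values here, none of the measured steps touches this nitrogen: each of them only exchanges a substituent on an aromatic carbon, and each stayed within the scatter. They are therefore only an indirect guide to the present change. Since every recorded change left the number essentially unmoved, the expected step is a 1.0-fold lower number from compound 3 to compound 4 (0.01 log units; within the scatter), again within the scatter and in no clear direction. Compound 4 is accordingly estimated at 180000 nM, with a range from 90000 nM to 360000 nM.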

Compound 4, half-maximal inhibitory concentration: 195000 nM
Estimate against measurement, compound 4: 1.1-fold (0.03 log units) below, within the range that was stated.
By their numbers in this assay, from the lowest: compounds 1, 2, 3 and 4 (each within the scatter of the next).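

Within the data shown here, the benzyl exchange is the first change here to reach the nitrogen itself rather than a substituent on an aromatic carbon. In this assay, benzyl in place of 4-fluorophenyl gives a 1.0-fold higher number from compound 3 to compound 4 (0.02 log units; within the scatter), benzyl in place of 4-methoxyphenyl gives a 1.1-fold higher number from compound 2 to compound 4 (0.05 log units; within the scatter), and benzyl in place of phenyl gives a 1.2-fold higher number from compound 1 to compound 4 (0.06 log units; within the scatter). This shows that, among these four compounds, exchanging the ring group on this nitrogen for benzyl cannot be distinguished on this read-out, whichever of the three groups leaves, and nothing available bears on why the numbers stay so close together.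

The compounds shown leave open whether a different kind of group on this nitrogen, such as a longer chain, a morpholine ring or a carboxylic acid, would move the number beyond the scatter. They also leave open what would happen if the chlorine shared by all four compounds gave way to an amine, since every change shown leaves that part of the shared core untouched.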